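Isobutoxy in place of ethyl on a bile acid receptor agonist

A few compounds are considered here, and "the series" means these few. Any claim that something is new, unique, unknown or untested is made for them only; others in the source may bear on it.

Compound 1 `Cc1nc(C(=O)O)nc2ccc(-c3ccc(OCc4c(-c5c(Cl)cccc5Cl)noc4C(C)C)cc3)cc12`: 140 nM
Compound 2 `CC(C)c1onc(-c2c(Cl)cccc2Cl)c1COc1ccc(-c2ccc3nc(C(=O)O)nnc3c2)cc1`: 360 nM
Compound 3 `CCc1cc(C(=O)O)nc2ccc(-c3ccc(OCc4c(-c5c(Cl)cccc5Cl)noc4C(C)C)cc3)cc12`: 75 nM

In a functional assay for agonist activity at Bile acid receptor (Homo sapiens), read by FRET (a lower number here means that less compound is needed, a higher number that more compound is needed for the effect), compound 3 gives the lowest of the three numbers. Compound 1 stands nearest to it, and the gap between the two lies within the scatter, so no order can be read between them. Compound 2 stands furthest away, with a gap beyond the scatter. Within the data shown here, none of the three measured compounds differs from another in only one place, so no single step is known on this core.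

Compound 4 `CC(C)COc1cc(C(=O)O)nc2ccc(-c3ccc(OCc4c(-c5c(Cl)cccc5Cl)noc4C(C)C)cc3)cc12` is the next one to follow. It differs from compound 3 in one place: isobutoxy in place of ethyl on an aromatic carbon. Among the measured compounds shown here, with no measured step of a related kind to lean on, the expected step is modest: a drift toward a somewhat higher number, but one that may well stay within the scatter. Compound 4 is therefore estimated at 110 nM, with a range from 35 nM to 350 nM, which would mean an expected step of a 1.5-fold higher number from compound 3 to compound 4 (0.17 log units; within the scatter).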

Compound 4, half-maximal effective concentration: 78 nM
Beside the measured number, compound 4's estimate is 1.4-fold (0.15 log units) above it; the range from low to high includes it.
By their numbers in this assay, from the lowest: compounds 3, 4 and 1 (each within the scatter of the next); then compound 2.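

In this assay, isobutoxy in place of ethyl on this aromatic carbon, opposite the ring nitrogen, gives a 1.0-fold higher number from compound 3 to compound 4 (0.02 log units; within the scatter) and so leaves the two compounds without an order. Among these compounds, this is the first single-place step known on this core: at this position, a group of five heavy atoms carrying one hydrogen-bond acceptor stands in for one of two heavy atoms with no acceptor, and the two values remain within the scatter of each other. No measured information at hand bears on the reason for this result.

The compounds shown leave open whether the same place would accept a different kind of group, such as an amine or a longer chain ending in a carboxylic acid. Isobutoxy also brings in the oxygen and the branched chain together, and a plain ethoxy group at this place would be needed to separate the two.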